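A few compounds are considered here, and "the series" means these few. Any claim that something is new, unique, unknown or untested is made for them only; others in the source may bear on it.

Working notes on the series, values from an ADME assay on MDCK cells (Canis lupus familiaris) for cytotoxicity, read by MTT assay, with a stated time of 72 h; on this read-out higher numbers stand for weaker inhibition and lower numbers for stronger inhibition:

- Compound 1 `COc1ccc(/C=C/C(=O)CC(C)=O)cc1OC`: 9900 nM
- Compound 2 `COc1ccc(/C=C/C(=O)CC(C)=O)cc1`: 41600 nM

Compound 2, at 41600 nM, has the higher number of the two measured compounds, so it shows the weaker inhibition in this assay. The next compound, compound 3 `CC(=O)CC(=O)/C=C/c1ccc(O)cc1`, is hydrogen in place of methyl on an oxygen on an aromatic ring. The same difference reads as methoxy to hydroxy.

For the measured compounds named here, only one measured step bears on this, and only loosely: a 4.2-fold higher number from compound 1 to compound 2 (0.62 log units; beyond the scatter), with hydrogen in place of methoxy on an aromatic carbon. That step removes a whole methoxy, whereas compound 3 keeps the oxygen, so it cannot be carried over directly. Going by the values given here, the data hold no measured example of methoxy to hydroxy, and two compounds show no trend. A small move towards a lower number is expected, but not one beyond the scatter. The estimated step is a 1.7-fold lower number from compound 2 to compound 3 (0.22 log units; within the scatter). For compound 3 the expected value is 25000 nM, with an estimated range from 9000 nM to 70000 nM.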

Compound 3, half-maximal inhibitory concentration: 30600 nM
The estimate for compound 3 lay 1.2-fold (0.09 log units) below the measured number, within the range that was stated.
By their numbers in this assay, from the lowest: compound 1; then compounds 3 and 2 (each within the scatter of the next).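

In this assay, for the compounds shown here, the first reading at the oxygen on the aromatic ring is a 1.4-fold lower number from compound 2 to compound 3 (0.13 log units; within the scatter) and lies within the scatter, so methoxy to hydroxy at this place gives no change that can be told apart from repeat measurements. The earlier step, a 4.2-fold higher number from compound 1 to compound 2 (0.62 log units; beyond the scatter) for hydrogen in place of methoxy on an aromatic carbon, lies beyond the scatter, so the two kinds of change on the ring do not read alike in this pair of steps. No measured property in hand accounts for that contrast.

The compounds shown leave open whether removing the methyl from the oxygen would also stay within the scatter on the core of compound 1, which carries two methoxy groups, since a single step at this oxygen gives no trend. They also leave open how other groups on the same oxygen or in the same place on the ring would read, such as a longer ether chain, an amine or a carboxylic acid, and whether any of these would move the number beyond the scatter.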